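A few compounds are considered here, and "the series" means these few. Any claim that something is new, unique, unknown or untested is made for them only; others in the source may bear on it.

Measured compounds:

- compound 1, `CCCCNc1ccc([N+](=O)[O-])cc1S(=O)(=O)NC`: in an assay on HEK293 cells for inhibition of solute carrier family 12 member 2 (Homo sapiens), read by fluorescence, with a stated time of 30 min, tested at 100 uM (on this read-out lower numbers stand for a weaker effect and higher numbers for a stronger effect at the one concentration tested), compound 1 gives 13.3%
- compound 2, `CCCCNc1ccc([N+](=O)[O-])cc1S(=O)(=O)N(C)C`: in this assay compound 2 gives 15.2%
- compound 3, `CCCCNc1ccc(C(=O)O)cc1S(N)(=O)=O`: in this assay compound 3 gives 6.4%

Among the measured compounds shown here, the one counted step among the measured compounds is methyl in place of hydrogen on a sulfonamide nitrogen. In this assay it reads a number 1.9 percentage points higher from compound 1 to compound 2 (within the scatter), so the two read-outs do not separate. Compound 3 carries a different core; how the core of compound 3 differs from the core of compound 1 is not broken down here, and its read-out in this assay sits within the scatter of both compound 1 and compound 2.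

Compound 4, `CCCCNc1ccc(C(=O)O)cc1S(=O)(=O)NC`, is not yet measured. It differs from compound 3 by methyl in place of hydrogen on a sulfonamide nitrogen. For the measured compounds named here, this is the same kind of change as the one from compound 1 to compound 2, not the same: in compound 1 the sulfonamide nitrogen already carries a saturated chain carbon besides the sulfonyl sulfur, whereas in compound 3 its only other neighbour is the sulfonyl sulfur. On the core of compound 1 the change moved the read-out by a number 1.9 percentage points higher from compound 1 to compound 2 (within the scatter), and with no other comparison available the step from compound 3 to compound 4 is expected to be of similar small size, a number 2.6 percentage points higher from compound 3 to compound 4 (within the scatter). Compound 4 is therefore estimated at 9% in this assay, with a likely range from 0% to 20%.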

Compound 4, a percentage reported as inhibition, at one concentration (the size of the read-out at that concentration, not a potency): 6.2%
The estimate for compound 4 lay 2.8 percentage points above the measured number; low and high end bracket the measured number.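

In this assay, methyl in place of hydrogen on a sulfonamide nitrogen reads a number 0.2 percentage points lower from compound 3 to compound 4 (within the scatter), and the two cores agree: the same change on two cores in this assay, a number 1.9 percentage points higher (within the scatter) from compound 1 to compound 2 and a number 0.2 percentage points lower (within the scatter) from compound 3 to compound 4, 2.1 percentage points apart, within the scatter of two such steps. Carboxy in place of nitro on an aromatic carbon reads a number 7.1 percentage points lower from compound 1 to compound 4 (within the scatter), so the two cores do not separate at the one concentration tested either. The change therefore carries over between these two cores only in the sense that neither step can be told from the scatter, which shows no real effect being transferred and says nothing about a core on which the read-out is larger.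

Still open, going by these compounds, is whether any change moves the read-out beyond the scatter, for example an ethyl group or a longer chain on the sulfonamide nitrogen, or an amide or a nitrile in place of carboxy on the aromatic carbon. Also open, on these data alone, is whether a longer chain in place of the butyl chain on the amine changes the picture.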